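Isopropyl for methyl on the triazene nitrogen

The source may hold more compounds than are shown below. What is called first, only, known or untested is meant among the compounds shown, and "the series" means these compounds.

The study covers two measured compounds in a functional assay on L1210 cells (Mus musculus) for antiproliferative activity; a lower number here means a less potent compound, a higher number a more potent compound, by a factor of ten per unit of this negative logarithm. Compound 1 `CN(/N=N/c1ccc(C(N)=O)cc1)c1cccs1` gives 2.9 in this assay. Compound 2 `CN(C)/N=N/c1ccc(C(N)=O)cc1` gives 3.51 in this assay, the higher of the two numbers recorded. Going by the values given here, the one step known so far, a number 0.61 log units higher from compound 1 to compound 2 (beyond the scatter), arose from methyl in place of thiophen-2-yl on an amine nitrogen.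

Compound 3 `CC(C)N(C)/N=N/c1ccc(C(N)=O)cc1` is not yet measured. It differs from compound 2 by isopropyl in place of methyl on an amine nitrogen. Among the compounds with values here, no measured step concerns isopropyl against methyl on that nitrogen, so the single known step offers no direct guide, and compound 2 is taken as the anchor. A step of no more than modest size in either direction is therefore expected. The step expected from this change is a number 0.21 log units lower from compound 2 to compound 3 (within the scatter). Compound 3 is estimated at 3.3 in this assay, within a range from 2.7 to 3.9.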

Compound 3, logarithm of the reciprocal of the active concentration, log(1/C): 3.17
The estimate for compound 3 lay 0.13 log units above the measured number; the range from low to high includes it.
By their numbers in this assay, from the lowest: compounds 1 and 3 (each within the scatter of the next); then compound 2.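

In this assay, the amine nitrogen whose other neighbours are a double-bonded nitrogen and a saturated chain carbon does not tolerate every replacement of methyl equally: isopropyl in place of methyl gives a number 0.34 log units lower from compound 2 to compound 3 (beyond the scatter) and so adds a saturated alkyl example to the aromatic one already seen. Isopropyl in place of thiophen-2-yl gives a number 0.27 log units higher from compound 1 to compound 3 (within the scatter), so the numbers do not separate these two groups, and the dimethylamino compound, compound 2, stays above both. Nothing available explains these differences.

The compounds shown leave open where ethyl, propyl or a longer chain would stand on this nitrogen, and whether a phenyl or cyclopropyl group would behave like thiophen-2-yl or isopropyl. They also leave open whether the isopropyl step would hold with a carboxylic acid on the shared core.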